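The source may report more compounds than this note shows. Statements on the series, on what has been measured and on what is new or still open speak of the compounds shown alone.

Measured compounds in a functional assay on CCRF-CEM cells (Homo sapiens) for cytotoxicity, with a stated time of 72 h; a higher number here means a weaker inhibitor, a lower number a stronger inhibitor:

compound 1 `COc1ccc(/C=C2\CCC/C(=C\c3ccccc3[N+](=O)[O-])C2=O)cc1`, 7450 nM
compound 2 `O=C1/C(=C/c2ccccc2)CCC/C1=C\c1ccc([N+](=O)[O-])cc1`, 9320 nM
compound 3 `O=C1/C(=C/c2ccccc2)CCC/C1=C\c1ccccc1[N+](=O)[O-]`, 925 nM

The account concerns one structural change seen twice. Between compound 3 and compound 1 the change is methoxy in place of hydrogen on an aromatic carbon and the measured result is an 8.1-fold higher number from compound 3 to compound 1 (0.91 log units; beyond the scatter). Compound 2 is built from the same atoms as compound 3, joined differently; the difference between the two cores is not broken down here. Against this background compound 4 `COc1ccc(/C=C2\CCC/C(=C\c3ccc([N+](=O)[O-])cc3)C2=O)cc1` is yet to be measured in this assay. It differs from compound 2 by methoxy in place of hydrogen on an aromatic carbon, the same change as between compound 3 and compound 1, at a place described in the same words.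

Within the data shown here, with only one earlier instance of the change, and on a different core, the expectation rests on that single step: the number for compound 4 is expected to move by a 5.9-fold higher number from compound 2 to compound 4 (0.77 log units; beyond the scatter), in line with the earlier step from compound 3 to compound 1. Accordingly compound 4 is estimated at 55000 nM in this assay, most likely between 15000 nM and 200000 nM.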

Compound 4, half-maximal inhibitory concentration: 250000 nM
The estimate for compound 4 lay 4.5-fold (0.66 log units) below the measured number; measured number outside the range, above it.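

In this assay, the change from phenyl to 4-methoxyphenyl gives a 27-fold higher number from compound 2 to compound 4 (1.43 log units; beyond the scatter), so the new step runs in the same direction as the earlier one. The two instances agree in direction but not in size: the same change on two cores in this assay, an 8.1-fold higher number (0.91 log units; beyond the scatter) from compound 3 to compound 1 and a 27-fold higher number (1.43 log units; beyond the scatter) from compound 2 to compound 4, 3.3-fold (0.52 log units) apart, beyond the scatter of two such steps. In this series, then, the direction of the change carried from one core to the other, while its size did not, so the step measured on one core gave no safe figure for the other; two pairs, however, do not show why the size differs, nor whether the direction would hold on any further core.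

The compounds shown leave open whether a hydroxy group, an ethoxy group or an amine on the same aromatic carbon would go with a higher number as methoxy does. They also leave open how a group other than nitro on the second aromatic ring would alter the size of the methoxy step.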